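Trading the pyridazin-3-yl group of compound 2

The compounds below may be only part of what the source reports. "The series", "measured", "known", "first", "only" and "open" are said of these compounds alone.

Measured so far in an ADME assay on a cell-free system (plasma, Homo sapiens) for protein binding, are three compounds.
Compound 1 `Cc1ccc([C@@H](C)Oc2cc3oc(=O)n(CCC(=O)O)c3cc2Cl)nc1` gives 97.8%
Compound 2 `C[C@@H](Oc1cc2oc(=O)n(CCC(=O)O)c2cc1Cl)c1cccnn1` gives 68.1%
Compound 3 `O=C(O)CCn1c(=O)oc2cc(OCc3ccccn3)c(Cl)cc21` gives 92.6%

Compound 2 has the highest unbound fraction of the three. Compound 4 `C[C@@H](Oc1cc2oc(=O)n(CCC(=O)O)c2cc1Cl)c1ccc(Cl)cn1` differs from it in one place (5-chloropyridin-2-yl in place of pyridazin-3-yl on a saturated chain carbon bound to an oxygen on an aromatic ring and a saturated chain carbon), where 5-chloropyridin-2-yl replaces pyridazin-3-yl on the saturated chain carbon. The closest measured change is large (a 15-fold higher unbound fraction from compound 1 to compound 2 (1.16 log units; beyond the scatter)), and it involves the same place, with 5-methylpyridin-2-yl as the partner group. A modest step (a 4.3-fold lower unbound fraction from compound 2 to compound 3 (0.63 log units; beyond the scatter)) also ends on a ring with 1 hetero atom. Going by the values given here, no measured compound carries 5-chloropyridin-2-yl. A large drop in unbound fraction is therefore expected in this assay for this change (a 16-fold lower unbound fraction from compound 2 to compound 4 (1.20 log units; beyond the scatter)). Compound 4 is estimated at 98% in a expected range of 96% to 99.2% for now.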

Compound 4, plasma protein binding: 99%
Compound 4: middle estimate off by 2.0-fold (0.30 log units) (unbound fraction), on the high side; low and high end bracket the measured number.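

In this assay, the ring on the saturated chain carbon gives the widest spread seen so far (a 32-fold lower unbound fraction from compound 2 to compound 4 (1.50 log units; beyond the scatter)). Even with the ring type kept, chloro in place of methyl on an aromatic carbon still shifts binding (a 2.2-fold lower unbound fraction from compound 1 to compound 4 (0.34 log units; beyond the scatter)), so the group carried by the ring matters, not just the ring itself. No measured evidence explains either shift. From the compounds shown here alone, it remains open whether chloro on the pyridazin-3-yl ring would have a similar effect. An amine on the ring might instead return the unbound fraction towards that of compound 2.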